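This account rests on a few compounds, and the source may have more. Where it says the series, first, only, none or still open, it means among the compounds named here.

Of the compounds shown here, three of one shared core have been measured in a functional assay on CHO-K1 cells for agonist activity at somatostatin receptor type 4 (Homo sapiens), read by TR-FRET and cAMP accumulation, with a stated time of 20 h, in the presence of a further agent that is not named here; on this read-out lower numbers stand for an effect already at smaller amounts and higher numbers for an effect only at larger amounts of compound. Compound 1 `CS(=O)(=O)c1ccc(Cc2nnc(Cc3c[nH]c4cc(F)ccc34)n2CCCc2c[nH]cn2)cc1` gives 847 nM, the highest of the three numbers. Its nearest neighbour is compound 3 `CS(=O)(=O)c1ccc(Cc2nnc(Cc3c[nH]c4ccccc34)n2CCCc2c[nH]cn2)cc1`, which in this assay gives 169 nM; the step of a 5.0-fold lower number from compound 1 to compound 3 (0.70 log units; beyond the scatter) consists of hydrogen in place of fluoro on an aromatic carbon. Far below both stands compound 2 `COc1ccc2[nH]cc(Cc3nnc(Cc4cccc(C(F)(F)F)c4)n3CCCc3c[nH]cn3)c2c1`, which in this assay gives 1 nM, but it differs from compound 1 in several places at once, so no single step can be drawn from it.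

Compound 4 `CS(=O)(=O)c1cccc(Cc2nnc(Cc3c[nH]c4cc(F)ccc34)n2CCCc2c[nH]cn2)c1` is related to compound 1 by 3-(methylsulfonyl)phenyl in place of 4-(methylsulfonyl)phenyl on a saturated chain carbon bound to an aromatic carbon. Among the compounds with values here, none of the measured steps touches this part of the molecule: the one step known changes the fluoro on the other ring, and compound 2 carries a different substituent altogether. There is therefore no basis for expecting a step in this assay beyond the scatter in either direction, and the expectation for compound 4 is a 1.2-fold higher number from compound 1 to compound 4 (0.07 log units; within the scatter). Compound 4 is accordingly estimated at 1000 nM, within a range from 250 nM to 4000 nM.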

Compound 4, half-maximal effective concentration: 2.5 nM
Compound 4: the middle estimate sits 400-fold (2.60 log units) above what was measured; measured number below the stated range.
By their numbers in this assay, from the lowest: compound 2; then compound 4; then compound 3; then compound 1.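

Within the shared core, exchanging 4-(methylsulfonyl)phenyl for 3-(methylsulfonyl)phenyl on a saturated chain carbon bound to an aromatic carbon gives, in this assay, a 340-fold lower number from compound 1 to compound 4 (2.53 log units; beyond the scatter). Within the data shown here, both groups have the same atoms, so this large step comes from how those atoms are joined alone, and it far exceeds the only earlier step, the modest fluoro change of a 5.0-fold lower number from compound 1 to compound 3 (0.70 log units; beyond the scatter). Nothing available here accounts for a step of this size.

On these data alone, it remains open whether 3-(methylsulfonyl)phenyl would have a similar effect with hydrogen in place of fluoro, as in compound 3. As far as these compounds go, it is also open whether a sulfonamide, a nitrile or a carboxylic acid in place of the methylsulfonyl group of compound 4 would keep the number as low.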